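Permeability notes: from compound 3 to compound 4

A few compounds are considered here, and "the series" means these few. Any claim that something is new, unique, unknown or untested is made for them only; others in the source may bear on it.

Measured so far:
Compound 1, `O=C(O[C@@H](C(=O)N1N=CC[C@H]1C(=O)NCc1cc(Cl)ccc1-n1cnnn1)c1ccc(F)cc1)c1ccccc1`, in an ADME assay on Caco-2 cells (Homo sapiens) for permeability, read by LC-MS, in the apical to basolateral direction, with a stated time of 60 min, at pH 6.5 (on this read-out lower numbers stand for lower permeability and higher numbers for higher permeability), compound 1 gives 43 10^-6 cm/s.
Compound 2, `CC1(C[C@@H](O)C(=O)N2C[C@H]3C[C@H]3[C@H]2C(=O)NCc2cc(Cl)ccc2-n2cnnn2)CC1`, in this assay compound 2 gives 2.2 10^-6 cm/s.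
Compound 3, `CC(C)(C)C[C@@H](O)C(=O)N1NCC[C@H]1C(=O)NCc1cc(Cl)ccc1-n1cnnn1`, in this assay compound 3 gives 15 10^-6 cm/s.

Compound 3 holds the second highest of the three numbers. Compound 1 is its nearest neighbour and sits above it, beyond the scatter; compound 2 is furthest away and sits below it, also beyond the scatter. None of the three pairs differs in a single place, so no measured step can be read off directly.

Compound 4, `O=C(NCc1cc(Cl)ccc1-n1cnnn1)[C@@H]1CCNN1C(=O)[C@H](O)c1ccccc1`, is not yet measured. Against compound 3 it differs by phenyl in place of neopentyl on a saturated chain carbon bound to a carbonyl carbon and an oxygen on a saturated carbon. Within the data shown here, no measured pair in the set shows this exchange on its own, and the remaining differences between compound 1 and compound 3 lie elsewhere in the structure, so the effect of the exchange itself is not isolated by any measured value.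

The step from compound 3 to compound 4 is therefore expected to be small, most likely within the usual scatter, a 1.3-fold lower number from compound 3 to compound 4 (0.10 log units; within the scatter). Compound 4 is estimated at 12 10^-6 cm/s in this assay, with a range from 5 10^-6 cm/s to 30 10^-6 cm/s.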

Compound 4, apparent permeability: 5.3 10^-6 cm/s
For compound 4 the middle estimate is 2.3-fold (0.35 log units) above the measured one; measured number inside the range.
By their numbers in this assay, from the lowest: compound 2; then compound 4; then compound 3; then compound 1.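

Phenyl in place of neopentyl on a saturated chain carbon bound to a carbonyl carbon and an oxygen on a saturated carbon is not a silent exchange in this assay and gives a 2.8-fold lower number from compound 3 to compound 4 (0.45 log units; beyond the scatter) as a modest step beyond the scatter. Among these compounds, this pair is the only one that differs in one place, so it gives the first direct reading of a change at this position, which compound 1 and compound 2 could not supply. The reading holds only for this exchange on the core shared by compound 3 and compound 4, and no measured evidence bears on what lies behind the step.

Still open, on these data alone, is how other groups at this place would read in this assay, for example a longer alkyl chain, a cyclohexyl ring, an amine or a carboxylic acid. Also open, as far as these compounds go, is whether the same exchange would give a step of similar size on the cores of compound 1 and compound 2, since neither compound has a partner here that differs from it in one place.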